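The source may report more compounds than this note shows. Statements on the series, on what has been measured and on what is new or still open speak of the compounds shown alone.

Working notes on the series, in an assay on isolated protein with Bile acid receptor (Homo sapiens) as the target; on this read-out lower numbers stand for an effect already at smaller amounts and higher numbers for an effect only at larger amounts of compound.

Compound 1 `COC(=O)/C=C/c1cccc(N(Cc2ccc(-c3ccc(F)c(F)c3)cc2)C(=O)C2CCCCC2)c1` gives 72 nM in this assay, the lowest of the two numbers recorded. Compound 3 `COC(=O)/C=C/c1cccc(N(Cc2ccc3c(c2OC)OC(C)(C)C=C3)C(=O)C2CCCCC2)c1` gives 358 nM in this assay, a higher number that lies beyond the usual scatter. Compound 2 `COC(=O)/C=C/c1cccc(N(Cc2cccc(Br)c2)C(=O)C2CCCCC2)c1` reaches only the limit of the assay and gives > 1000 nM; that is a limit, not a number, and one of the three values shown sits there (the limit of > 1000 nM in this assay, at which 1 of the 3 values shown sits). Going by the values given here, no pair of measured compounds differs in a single place, so no measured step is available to anchor a prediction.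

Compound 4 `COC(=O)/C=C/c1cccc(N(Cc2ccc(/C=C/c3c(Cl)cccc3Cl)cc2)C(=O)C2CCCCC2)c1` has not yet been measured in this assay. It differs from compound 1 in one place: 2-(2,6-dichlorophenyl)ethenyl in place of 3,4-difluorophenyl on an aromatic carbon.

Both neighbours of compound 1 with altered benzyl substituents, compound 3 and compound 2, give higher numbers, and the replacement in compound 4 is a larger group than the one it replaces. The expected step is a 2.5-fold higher number from compound 1 to compound 4 (0.40 log units; beyond the scatter), a move toward a higher number, of a size at the edge of or somewhat beyond the scatter. Compound 4 is accordingly expected to give about 180 nM in this assay, with a likely range from 60 nM to 600 nM.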

Compound 4, half-maximal effective concentration: 150 nM
Beside the measured number, compound 4's estimate is 1.2-fold (0.08 log units) above it; the measured number falls inside the stated range.
By their numbers in this assay, from the lowest: compound 1; then compound 4; then compound 3. At a limit, above all of these: compound 2.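

In this assay, the aromatic carbon para to a large group now has its first measured single-place change, and a 2.1-fold higher number from compound 1 to compound 4 (0.32 log units; beyond the scatter) is the reading for 2-(2,6-dichlorophenyl)ethenyl in place of 3,4-difluorophenyl. The step lies beyond the scatter but stays modest: the entering group has 10 heavy atoms and a double bond outside aromatic rings, and compound 4 still gives 150 nM in this series. No measured property among the data shown bears on this step, and its origin remains unassigned.

The change replaces two features at once, the fluorine atoms by chlorine atoms and a direct ring attachment by an ethenyl link, so this one step cannot apportion its size between them; 2,6-dichlorophenyl attached directly and 2-(3,4-difluorophenyl)ethenyl would separate the two. The compounds shown also leave open how this position responds to a group of another kind, such as an amine or a carboxylic acid, since both groups compared here are free of hydrogen-bond donors, hydrogen-bond acceptors and net charge.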